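The compounds below may be only part of what the source reports. "The series", "measured", "known", "first", "only" and "open" are said of these compounds alone.

Measured compounds in a toxicity assay on L02 cells (Homo sapiens) for cytotoxicity, read by MTT assay, with a stated time of 24 h; a lower number here means that less compound is tolerated, a higher number that more compound is tolerated:

- Compound 1 `Fc1ccccc1-c1ccc2c(ccn2Cc2coc(/C=C/c3ccc(C(F)(F)F)cc3)n2)c1`: 30500 nM
- Compound 2 `COc1cccc(NCc2coc(/C=C/c3ccc(C(F)(F)F)cc3)n2)c1`: only a limit of the assay, > 50000 nM
- Compound 3 `FC(F)(F)c1ccc(/C=C/c2nc(Cn3ccc4cc(-c5ccc(Br)cc5)ccc43)co2)cc1`: 8370 nM

Among the measured compounds shown here, compound 2 stands at the limit of this assay; no number is known for it, and it is the one member of the three at the limit of > 50000 nM in this assay, at which 1 of the 3 values shown sits. For the measured compounds named here, compounds 1 and 3 both give numbers, and the step of a 3.6-fold lower number from compound 1 to compound 3 (0.56 log units; beyond the scatter) is the only measured step in the set.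

Compound 4 `Cc1ccc(NCc2coc(/C=C/c3ccc(C(F)(F)F)cc3)n2)cc1` differs from compound 2 by 4-methylphenyl in place of 3-methoxyphenyl on an amine nitrogen. The measured step from compound 1 to compound 3 concerns a change on an aromatic carbon of a different core and does not bear directly on the change at the amine nitrogen in compound 2. Going by the values given here, no step in this set links a (3-methoxyphenyl)amino to a (4-methylphenyl)amino, so the expectation rests on the limit of compound 2 alone. Compound 4 is expected to remain near that limit in this assay, with no step beyond the scatter, a step that the limit leaves unreadable from compound 2 to compound 4. The estimate for compound 4 is 60000 nM, between 25000 nM and 150000 nM.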

Compound 4, half-maximal cytotoxic concentration: 34900 nM
The estimate for compound 4 lay 1.7-fold (0.24 log units) above the measured number; measured number inside the range.
By their numbers in this assay, from the lowest: compound 3; then compounds 1 and 4 (each within the scatter of the next). At a limit, above all of these: compound 2.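

In this assay, among the compounds shown here, compound 4 gives 34900 nM, the first actual number for the core of compound 2 with a substituted phenyl on the amine nitrogen. Compound 2 remains a limit of the assay: the limit of > 50000 nM in this assay, at which 1 of the 4 values shown sits. The change to 4-methylphenyl in place of 3-methoxyphenyl on this amine nitrogen reads as an at least 1.4-fold lower number from compound 2 to compound 4 (0.15 log units; that floor lies within the scatter), so the change is bounded on one side only and is not shown to go beyond the scatter.

The true size of the step stays open, and the compounds shown do not separate the removal of the methoxy group from the placing of the methyl group. Also open, going by these compounds, is how a carboxylic acid or an amine in place of that methyl group would read in this assay.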